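This account rests on a few compounds, and the source may have more. Where it says the series, first, only, none or still open, it means among the compounds named here.

The measured compounds in a functional assay on MCF7 cells (Homo sapiens) for cytotoxicity, read by neutral red uptake, with a stated time of 3 days (a higher number here means a weaker inhibitor, a lower number a stronger inhibitor), are these. Compound 1 `Nc1ccc(-c2cc(=O)c3c(N)c(F)c(O)c(F)c3o2)cc1F` gives > 10000 nM, which is a limit of the assay rather than a number. Compound 2 `Nc1ccc(-c2cc(=O)c3c(N)c(F)c(CO)c(F)c3o2)cc1F` gives 62 nM. Compound 3 `COCc1c(F)c(N)c2c(=O)cc(-c3ccc(N)c(F)c3)oc2c1F` gives 46 nM.

On the numbers shown, compound 1 stands only at a limit, namely (the limit of > 10000 nM in this assay, at which 1 of the 3 values shown sits), so how weak it truly is cannot be read off. Compound 4 `CCCOCc1c(F)c(N)c2c(=O)cc(-c3ccc(N)c(F)c3)oc2c1F` has not yet been measured. It differs from compound 1 in one place: propoxymethyl in place of hydroxy on an aromatic carbon.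

Among the compounds with values here, two measured steps bear on this change, since both replace the same hydroxy with a group carrying a saturated carbon. The first is an at least 160-fold lower number from compound 1 to compound 2 (2.20 log units; beyond the scatter). The second is an at least 210-fold lower number from compound 1 to compound 3 (2.33 log units; beyond the scatter). Both are large and both point the same way, toward a lower number. Between those two products, a 1.3-fold lower number from compound 2 to compound 3 (0.13 log units; within the scatter), so adding a methyl on the oxygen changed little. A propoxymethyl is again an ether on that carbon, so a large step downward from compound 1 is expected, of a size close to the two measured ones.

Compound 4 is therefore estimated at about 70 nM, with a range from 20 nM to 300 nM. This expectation corresponds to an at least 140-fold lower number from compound 1 to compound 4 (2.15 log units; beyond the scatter).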

Compound 4, half-maximal inhibitory concentration: 1200 nM
For compound 4 the middle estimate is 17-fold (1.23 log units) below the measured one; the measured number lies above the stated range.
By their numbers in this assay, from the lowest: compounds 3 and 2 (each within the scatter of the next); then compound 4. At a limit, above all of these: compound 1.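

Chain length on the oxygen matters at this aromatic carbon in this assay. The earlier methyl on the oxygen gave a 1.3-fold lower number from compound 2 to compound 3 (0.13 log units; within the scatter), whereas the propyl on the oxygen gives a 19-fold higher number from compound 2 to compound 4 (1.29 log units; beyond the scatter), and extending the methoxymethyl by an ethyl gives a 26-fold higher number from compound 3 to compound 4 (1.42 log units; beyond the scatter). An ether on this carbon is therefore not enough on its own to hold the low numbers of compound 2 and compound 3, although the propoxymethyl in place of hydroxy still gives an at least 8.3-fold lower number from compound 1 to compound 4 (0.92 log units; beyond the scatter). Compound 1 stands only at a limit of the assay, not at a number, so that step has no fixed size: the limit of > 10000 nM in this assay, at which 1 of the 4 values shown sits.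

The compounds shown leave open how the number moves along the chain: an ethoxymethyl or a butoxymethyl on this carbon could show whether it climbs steadily or jumps at one particular length. They also leave open how a chain ending in something other than an alkyl ether, such as an aminomethyl or a carboxylic acid, would compare on this same carbon.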